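From 4-hydroxycyclohexyl to (4-hydroxycyclohexyl)methyl on the shared core

The source may hold more compounds than are shown below. What is called first, only, known or untested is meant among the compounds shown, and "the series" means these compounds.

In an ADME assay on S9 fraction from liver (Homo sapiens) for metabolic stability, with a stated time of 1 h (a higher number here means that more of the compound is left, a lower number that less of the compound is left), compound 1 `N#Cc1cnc(NCc2cnccc2C(F)(F)F)cc1N[C@H]1CC[C@@H](O)CC1` gives 33%, and compound 2 `N#Cc1cnc(NCc2cnccc2C(F)(F)F)cc1N[C@H]1CC[C@H](O)CC1` gives 30%. Going by the values given here, these two values cannot be told apart: the only measured step is a number 3 percentage points lower from compound 1 to compound 2 (within the scatter), and it comes with the fact that compounds 1 and 2 differ only in the configuration as drawn. Compound 3 `N#Cc1cnc(NCc2cnccc2C(F)(F)F)cc1NC[C@H]1CC[C@@H](O)CC1` has not yet been measured. It carries (4-hydroxycyclohexyl)methyl in place of 4-hydroxycyclohexyl on a nitrogen on an aromatic ring. Among the compounds with values here, the one measured step concerns configuration alone, so it offers no direct guide to this change. The expectation therefore starts from compound 2 at 30%, and no change beyond the scatter is expected in this assay. The expected step is a number 2 percentage points lower from compound 2 to compound 3 (within the scatter). For compound 3 the estimated value is 28%, with an expected range from 12% to 46%.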

Compound 3, percent of the compound remaining: 41%
Estimate against measurement, compound 3: 13 percentage points below, and the stated range covers the measured number.
By their numbers in this assay, from the lowest: compounds 2, 1 and 3 (each within the scatter of the next, the first and the last beyond it).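

In this assay, going by these compounds alone, (4-hydroxycyclohexyl)methyl in place of 4-hydroxycyclohexyl on a nitrogen on an aromatic ring is the first change here that goes beyond configuration, and it reads as a number 11 percentage points higher from compound 2 to compound 3 (beyond the scatter). Set against the other starting compound, the same change reads as a number 8 percentage points higher from compound 1 to compound 3 (within the scatter), so the rise is clear against only one of the two. The position thus accepts the larger group with no loss in the compound left, and the two readings start from closely matched compounds: the fact that compounds 1 and 2 differ only in the configuration as drawn

From the compounds shown here alone, it stays open whether configuration counts for as little on the (4-hydroxycyclohexyl)methyl group as on 4-hydroxycyclohexyl. Going by these compounds, it is also open whether the hydroxyl group matters to this result, which an amine in its place could test, and whether a longer chain would continue the trend.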